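A few compounds are considered here, and "the series" means these few. Any claim that something is new, unique, unknown or untested is made for them only; others in the source may bear on it.

Measured compounds in an assay on HEK293 cells for displacement of a labelled ligand from C-X-C chemokine receptor type 3 (Homo sapiens); on this read-out lower numbers stand for stronger inhibition and higher numbers for weaker inhibition:
Compound 1 `CN(CC1=CC[C@H]2C[C@@H]1C2(C)C)Cc1ccc(-c2ccccc2)cc1` — 3160 nM
Compound 2 `CN(CC1=CC[C@H]2C[C@@H]1C2(C)C)Cc1cccc(-c2ccccc2)c1` — > 316 nM, a limit of the assay
Compound 3 `CN(CC1=CC[C@H]2C[C@@H]1C2(C)C)Cc1ccc(-c2ccc(C(F)(F)F)cc2)cc1` — > 316 nM, a limit of the assay

All three share the same core and differ only in the aromatic part carried on the basic nitrogen. Within the data shown here, compound 1 is the one that gives a number in this assay, 3160 nM. For compound 2 the assay reports only a limit, > 316 nM. For compound 3 the assay likewise reports only a limit, > 316 nM. Among the measured compounds shown here, the one change on the distal ring that is recorded, a step that the limit leaves unreadable from compound 1 to compound 3, therefore cannot be read in size.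

Compound 4 `CC(=O)c1cccc(-c2ccc(CN(C)CC3=CC[C@H]4C[C@@H]3C4(C)C)cc2)c1` differs from compound 1 by acetyl in place of hydrogen on an aromatic carbon. For the measured compounds named here, no measured step speaks readably to this change, since the related step from compound 1 to compound 3 sits at the limit of > 316 nM in this assay, at which 2 of the 3 values shown sit. The expectation for compound 4 rests on compound 1 alone, with a step estimated as a 1.3-fold lower number from compound 1 to compound 4 (0.10 log units; within the scatter), not beyond the usual scatter in either direction. Compound 4 is therefore estimated at 2500 nM in this assay, with a range from 600 nM to 10000 nM.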

Compound 4, inhibition constant: > 316 nM
Compound 4: only a limit was reported; the forecaster's own chance of this, stated with the estimate: 40%; the middle value is on the limit's open side.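

Among these compounds, compound 4 gives only a limit of the assay, > 316 nM, so the step from compound 1 to compound 4 cannot be read in size, and no new step emerges. The compounds shown leave open whether acetyl or trifluoromethyl on the outer ring changes the number of compound 1 in this assay, and in which direction.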